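Swapping the aryl nitrile for a fluorophenyl on the core

The source may report more compounds than this note shows. Statements on the series, on what has been measured and on what is new or still open speak of the compounds shown alone.

Measured compounds in a functional assay on QG-56 cells (Homo sapiens) for antiproliferative activity; on this read-out higher numbers stand for weaker inhibition and lower numbers for stronger inhibition:
compound 1, `Cn1cncc1C(O)(c1ccc(C#N)cc1)c1cc2cc([N+](=O)[O-])cc(-c3cccc(C#N)c3)c2o1`: 22.9 nM
compound 2, `COc1cccc(-c2cc(CO)cc3cc(C(O)(c4ccc(C#N)cc4)c4cncn4C)oc23)c1`: 16.8 nM
compound 3, `COc1cccc(-c2cc(C(N)=O)cc3cc(C(O)(c4ccc(C#N)cc4)c4cncn4C)oc23)c1`: 8.2 nM

Compound 1 gives the highest of the three numbers, although its gap to compound 2 lies within the scatter, while compound 3 sits lower by a gap beyond the scatter. For the measured compounds named here, the one step between compounds that differ in a single place, a 2.0-fold lower number from compound 2 to compound 3 (0.31 log units; beyond the scatter), concerns the substituent at a different place on the core and does not touch the aryl group that is changed here.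

Compound 4, `Cn1cncc1C(O)(c1ccc(C#N)cc1)c1cc2cc([N+](=O)[O-])cc(-c3ccc(F)cc3)c2o1`, arises from compound 1 by the change (4-fluorophenyl in place of 3-cyanophenyl on an aromatic carbon). Going by the values given here, no measured step involves this aryl group, so there is nothing in the data to argue for a move in either direction beyond the scatter. Compound 4 is therefore expected to give a number close to that of compound 1 in this assay, with a step of about a 1.1-fold higher number from compound 1 to compound 4 (0.04 log units; within the scatter). The estimate for compound 4 is 25 nM, with a range from 10 nM to 65 nM.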

Compound 4, half-maximal inhibitory concentration: 158 nM
For compound 4 the middle estimate is 6.3-fold (0.80 log units) below the measured one; the measured number lies above the stated range.
By their numbers in this assay, from the lowest: compound 3; then compounds 2 and 1 (each within the scatter of the next); then compound 4.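

Replacing 3-cyanophenyl with 4-fluorophenyl gives a 6.9-fold higher number from compound 1 to compound 4 (0.84 log units; beyond the scatter) in this assay on the shared core, which shows that the aryl group at this aromatic carbon, meta to a nitro group, is not interchangeable. This step is larger than the only earlier one, a 2.0-fold lower number from compound 2 to compound 3 (0.31 log units; beyond the scatter) at a different place on the core, so the aryl position can move this read-out at least as much as that substituent does. No available data explain the step.

The change removes the nitrile, adds fluorine and alters the substituent's place on the phenyl ring at once, so the compounds shown cannot separate these contributions. Going by these compounds, it remains open how 4-cyanophenyl, 3-fluorophenyl or unsubstituted phenyl would read at this position, and whether an aminophenyl group would behave like either measured aryl group.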